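A longer tail with more nitrogen: estimating compound 4

The source may hold more compounds than are shown below. What is called first, only, known or untested is meant among the compounds shown, and "the series" means these compounds.

Of the compounds shown here, three sharing one core have been measured in a functional assay on the whole organism with Rattus norvegicus as the target, at a dose of 100 mg/kg; on this read-out higher numbers stand for more inhibition at the one dose given (going by the name of the read-out) and lower numbers for less inhibition. Compound 1 `CC/N=C(\S)NCCCCCCn1nc(-c2ccccc2)ccc1=O` gives -5.6%, compound 2 `C/N=C(\S)N(C)CCCCn1nc(-c2ccccc2)ccc1=O` gives 17.5%, and compound 3 `N#CNC(=N)NCCCCn1nc(-c2ccccc2)ccc1=O` gives 61.2%. Compound 1 thus stands lowest of the three, with compound 2 nearest to it and compound 3 furthest away.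

Compound 4 `CN(C)/C(=N/CCCCCn1nc(-c2ccccc2)ccc1=O)NC#N` differs from compound 1 as follows: a group of 8 heavy atoms (4 carbon, 4 nitrogen; no ring) in place of a group of 7 heavy atoms (4 carbon, 2 nitrogen, 1 sulfur; no ring), on a saturated chain carbon, five bonds along the chain from an aromatic nitrogen. The group that enters carries no sulfur and holds a triple bond, which makes it resemble the group that enters in compound 3 rather than that in compound 2.

Going by the values given here, two measured steps bear on this change. The step of a number 23.1 percentage points higher from compound 1 to compound 2 (beyond the scatter) swapped the sulfur-bearing group of compound 1 for a smaller one that still contains sulfur, and only a modest rise followed. The step of a number 66.8 percentage points higher from compound 1 to compound 3 (beyond the scatter) put a nitrogen-only group with a triple bond in the same place and produced a large rise, and the step of a number 43.7 percentage points higher from compound 2 to compound 3 (beyond the scatter) points the same way. A large rise in this assay is therefore expected for compound 4, though the different chain length and the added atoms leave the size uncertain, so the range is wide.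

Compound 4 is expected to give 45%, with a range from 15% to 75%. This estimate means an expected step of a number 50.6 percentage points higher from compound 1 to compound 4 (beyond the scatter).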

Compound 4, a percentage reported as inhibition, in the whole organism at one dose (the size of the read-out at that dose, not a potency): 63.9%
The estimate for compound 4 lay 18.9 percentage points below the measured number; measured number inside the range.
By their numbers in this assay, from the lowest: compound 1; then compound 2; then compounds 3 and 4 (each within the scatter of the next).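

In this assay, a number 69.5 percentage points higher from compound 1 to compound 4 (beyond the scatter) shows that a large rise also comes with a second sulfur-free group holding a triple bond, here with 8 heavy atoms and placed on a saturated chain carbon, five bonds along the chain from an aromatic nitrogen. Compound 3 and compound 4 lie within the scatter of each other, so across these four compounds the two groups with a triple bond and no sulfur stand apart from the two sulfur-bearing groups in compound 1 and compound 2, and the different group size and place in compound 4 bring no visible loss at this single dose. No measurement shown here explains why this change raises the number.

On these data alone, each step changes several features at once, so it remains open whether the rise follows the loss of sulfur, the triple bond or the added nitrogen atoms. As far as these compounds go, it is also open whether a plain amine or a carboxylic acid at this place, or a longer chain carrying the same group as compound 4, would keep the number at this level.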